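Dimethoxyphenyl change from compound 2 to compound 3

The source may report more compounds than this note shows. Statements on the series, on what has been measured and on what is new or still open speak of the compounds shown alone.

compound 1 (`COc1cccc(/C=C/C(=O)c2cccc(-n3cc(COc4ccc5ccc(=O)oc5c4)nn3)c2)c1OC`): 11100 nM in a functional assay on HuCC-A1 cells (Homo sapiens) for cytotoxicity, read by MTT assay, with a stated time of 48 h; a higher number here means a weaker inhibitor, a lower number a stronger inhibitor
compound 2 (`COc1ccc(/C=C/C(=O)c2cccc(-n3cc(COc4cc(=O)oc5ccccc45)nn3)c2)cc1OC`): 38600 nM in this assay

Compound 2 holds the higher of the two numbers, beyond the scatter from compound 1, and so is the weaker inhibitor of the pair. Compound 3 (`COc1cccc(/C=C/C(=O)c2cccc(-n3cc(COc4cc(=O)oc5ccccc45)nn3)c2)c1OC`) differs from compound 2 by one change (2,3-dimethoxyphenyl in place of 3,4-dimethoxyphenyl on a double-bonded chain carbon bound to a double-bonded chain carbon). Going by the values given here, no measured step shows this change, so only a moderate step towards lower numbers in this assay is expected, because compound 1 gives 11100 nM and sets the only lower reference. The expected change is a 1.8-fold lower number from compound 2 to compound 3 (0.26 log units; within the scatter) and remains uncertain. For compound 3 the estimate is 21000 nM with 9000 nM to 45000 nM as the expected range.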

Compound 3, half-maximal inhibitory concentration: 2360 nM
For compound 3 the middle estimate is 8.9-fold (0.95 log units) above the measured one; measured number below the stated range.
By their numbers in this assay, from the lowest: compound 3; then compound 1; then compound 2.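

Replacing 3,4-dimethoxyphenyl with 2,3-dimethoxyphenyl on the double-bonded chain carbon gives a 16-fold lower number from compound 2 to compound 3 (1.21 log units; beyond the scatter) in this assay, so the arrangement of the two methoxy groups alone matters greatly at this position, with the atoms unchanged. With 2,3-dimethoxyphenyl held fixed, exchanging one group of 11 heavy atoms for another on the oxygen on a saturated carbon gives a 4.7-fold lower number from compound 1 to compound 3 (0.67 log units; beyond the scatter), so the number also depends on this second site. Nothing available explains either step.

As far as these compounds go, it remains open whether an aminophenyl or a hydroxyphenyl in place of 2,3-dimethoxyphenyl would keep the number of compound 3. From the compounds shown here alone, it also remains open whether the step from 3,4-dimethoxyphenyl recurs with the group carried by compound 1.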